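The source may hold more compounds than are shown below. What is called first, only, known or untested is meant among the compounds shown, and "the series" means these compounds.

Compound 1 `CCOC(=O)c1c(-c2cccc(-c3ccccc3)c2)[nH]c2cc(OC)ccc2c1=O` carries a phenyl group on the shared core. In an ADME assay on HepG2 cells (Homo sapiens) for cytotoxicity, read by luminescence, with a stated time of 72 h (on this read-out lower numbers stand for an effect already at smaller amounts and higher numbers for an effect only at larger amounts of compound), compound 1 gives > 21500 nM, which is a limit of the assay rather than a number. Compound 2 `CCCCOc1cccc(-c2[nH]c3cc(OC)ccc3c(=O)c2C(=O)OCC)c1` is measured at > 21500 nM, also a limit. Compound 3 `CCOC(=O)c1c(-c2cccc(C(F)(F)F)c2)[nH]c2cc(OC)ccc2c1=O` likewise gives > 21500 nM, a limit. The three steps among them, a step that the two limits leave unreadable from compound 1 to compound 2, a step that the two limits leave unreadable from compound 1 to compound 3 and a step that the two limits leave unreadable from compound 2 to compound 3, cannot be read in size because of the limit of > 21500 nM in this assay, at which 3 of the 3 values shown sit. Compound 4 `CCOC(=O)c1c(-c2cccc(CO)c2)[nH]c2cc(OC)ccc2c1=O` has not yet been measured; it differs from compound 1 by hydroxymethyl in place of phenyl on an aromatic carbon. Going by the values given here, none of the measured steps gives a readable change in this assay, so no direction can be drawn from them; they show only that exchanging the phenyl for other groups has left every value at the limit. Compound 4 is therefore expected to behave the same way, with an estimate of 30000 nM and a range from 15000 nM to 80000 nM. The expected step, a step that the limit leaves unreadable from compound 1 to compound 4, is estimated to be nothing beyond the scatter, and the likeliest outcome is again a limit.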

Compound 4, half-maximal effective concentration: > 21500 nM
Compound 4: no number, only a limit; the forecaster's own chance of this, stated with the estimate: 85%; the middle value lies beyond the limit too.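

Compound 4 gives only a limit, so its steps from compound 1, compound 2 and compound 3 in this assay cannot be read in size: the limit of > 21500 nM in this assay, at which 4 of the 4 values shown sit. The compounds shown leave open whether these four differ at all, and whether any change on the shared core would give a readable number.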